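The compounds below may be only part of what the source reports. "The series", "measured", "known", "first", "only" and "open" are said of these compounds alone.

Working notes on the nitrophenyl series.

Three compounds in the series have a number in a physicochemical assay for lipophilicity; a lower number here means a more polar compound, a higher number a more lipophilic compound. Compound 1 `COc1cc(/C=C2\CCC/C(=C\c3ccccc3[N+](=O)[O-])C2=O)cc(OC)c1OC` gives 4.86. Compound 2 `COc1ccc(/C=C2\CCC/C(=C\c3ccccc3[N+](=O)[O-])C2=O)cc1`, with the same shared core and a single methoxy on the other aryl ring, gives 4.86. Compound 3 `COc1cc(/C=C2\CCC/C(=C\c3cccc([N+](=O)[O-])c3)C2=O)cc(OC)c1OC` gives 5.06. Within the data shown here, the only single-point step among them is a number 0.20 log units higher from compound 1 to compound 3 (within the scatter), so the move of the nitro group from the 2-nitrophenyl to the 3-nitrophenyl changed nothing beyond the scatter. Compound 3 thus stands level with compound 1 and with compound 2 in this assay; the value of compound 2 lies within the scatter of that of compound 3 as well.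

Compound 4 `COc1cc(/C=C2\CCC/C(=C\c3ccc([N+](=O)[O-])cc3)C2=O)cc(OC)c1OC` is not yet measured. Its difference from compound 3 is 4-nitrophenyl in place of 3-nitrophenyl on a double-bonded chain carbon bound to a double-bonded ring carbon, again a shift of the nitro group around the same ring. Among the measured compounds shown here, the one step that bears on it, the step from compound 1 to compound 3, was within the scatter, so the expected step of a number 0.06 log units lower from compound 3 to compound 4 (within the scatter) is likewise expected to stay within the scatter, with no direction beyond it. Compound 4 is therefore estimated at 5 in this assay, with a range from 4.7 to 5.4.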

Compound 4, partition coefficient: 5.08
Estimate against measurement, compound 4: 0.08 log units below; the measured number falls inside the stated range.
By their numbers in this assay, from the lowest: compounds 1, 2, 3 and 4 (each within the scatter of the next).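

On a double-bonded chain carbon bound to a double-bonded ring carbon, 4-nitrophenyl in place of 3-nitrophenyl gives in this assay (a number 0.02 log units higher from compound 3 to compound 4 (within the scatter)) and 4-nitrophenyl in place of 2-nitrophenyl gives (a number 0.22 log units higher from compound 1 to compound 4 (within the scatter)). The earlier compounds offered only the step from 2-nitrophenyl to 3-nitrophenyl, whereas all three nitrophenyl groups can now be compared on the same shared core, and no listed step among compounds 1, 3 and 4 lies beyond the scatter. At this place, on this core, the choice among the three nitrophenyl groups therefore does not separate the compounds in this assay and nothing available accounts for the three standing level.

From the compounds shown here alone, what stays open is whether a different group at this place, such as an amine or a carboxylic acid on the phenyl ring instead of the nitro group, would give a step beyond the scatter. Also open, going by these compounds, is whether 3-nitrophenyl and 4-nitrophenyl would stand level with 2-nitrophenyl on the core of compound 2, with its single methoxy on the other aryl ring.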